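From 4-chlorophenyl to 4-bromophenyl

The compounds below may be only part of what the source reports. "The series", "measured", "known", "first", "only" and "open" are said of these compounds alone.

Compound 1 `COc1ccc(-c2nn(-c3ccccc3)cc2CNc2ccc(Br)cc2)cc1` gives 8060 nM
Compound 2 `Cc1ccc(-c2nn(-c3ccccc3)cc2CNc2ccc(Br)cc2)cc1` gives 6760 nM
Compound 3 `Clc1ccc(-c2nn(-c3ccccc3)cc2CNc2ccc(Br)cc2)cc1` gives 3010 nM

In a functional assay on B16-F10 cells (Mus musculus) for antiproliferative activity, read by MTT assay, with a stated time of 48 h (on this read-out lower numbers stand for stronger inhibition and higher numbers for weaker inhibition), compound 3 has the lowest number of the three, and its gaps to both others lie beyond the scatter. Compound 4 `Brc1ccc(NCc2cn(-c3ccccc3)nc2-c2ccc(Br)cc2)cc1` carries bromo in place of chloro on an aromatic carbon, para to a large group (bromo in place of chloro on an aromatic carbon). Chloro in place of methoxy gave a 2.7-fold lower number from compound 1 to compound 3 (0.43 log units; beyond the scatter) and chloro in place of methyl gave a 2.2-fold lower number from compound 2 to compound 3 (0.35 log units; beyond the scatter), both modest, while methyl in place of methoxy gave a 1.2-fold lower number from compound 1 to compound 2 (0.08 log units; within the scatter). For the measured compounds named here, no measured step exchanges one halogen for another, so these steps bear on it only indirectly. The expected step is a 1.0-fold lower number from compound 3 to compound 4 (0.02 log units; within the scatter), which means none beyond the scatter in this assay. Compound 4 is estimated at 2900 nM, with an expected range from 1300 nM to 6000 nM.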

Compound 4, half-maximal inhibitory concentration: 5270 nM
The estimate for compound 4 lay 1.8-fold (0.26 log units) below the measured number; low and high end bracket the measured number.
By their numbers in this assay, from the lowest: compounds 3, 4, 2 and 1 (each within the scatter of the next, the first and the last beyond it).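

In this assay exchanging one halogen for the other gives a 1.8-fold higher number from compound 3 to compound 4 (0.24 log units; within the scatter) and so leaves chloro and bromo at this position indistinguishable. In place of the other two groups, bromo gives a 1.3-fold lower number from compound 2 to compound 4 (0.11 log units; within the scatter) and a 1.5-fold lower number from compound 1 to compound 4 (0.18 log units; within the scatter) and so does not repeat the separation that chloro showed from methyl and methoxy. Among the groups shown, only chloro stands clear of any other group at this position, and only by modest steps.

On these data alone, whether fluoro, a nitrile or an amine on this carbon would give a number clear of these four remains open. Nothing available explains why chloro and bromo differ in their separation from methyl and methoxy.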